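Swapping the Amine Ring: Expected Volume of Distribution

This account rests on a few compounds, and the source may have more. Where it says the series, first, only, none or still open, it means among the compounds named here.

Measured compounds:
compound 1 `CN(C)C1CCN(c2cccc3nc(CN(C)[C@H]4CCCc5cccnc54)cn23)CC1`: 5.1 L/kg
compound 2 `CCCN(Cc1cn2c(N3CCN(C)CC3)cccc2n1)[C@H]1CCCc2cccnc21`: 6.2 L/kg
compound 3 `CN(C)[C@H]1CCN(c2cccc3nc(CN(C)[C@H]4CCCc5cccnc54)cn23)C1`: 4.5 L/kg

These three compounds were examined in an in vivo ADME assay on the whole organism for pharmacokinetics, with Rattus norvegicus as the target, at a dose of 1 mg/kg by the intravenous route; a higher number here means that more of the compound sits outside the plasma, a lower number that more of the compound stays in the plasma. Among them compound 3 shows the lowest number, though its nearest neighbour is compound 1 and the gap between them is within the scatter, and even compound 2, the furthest away, lies within the scatter of compound 3. Going by the values given here, the only step that touches the same aromatic carbon is a 1.1-fold lower number from compound 1 to compound 3 (0.05 log units; within the scatter), which did not move the read-out beyond the scatter.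

Compound 4 `CN1CCN(c2cccc3nc(CN(C)[C@H]4CCCc5cccnc54)cn23)CC1` is the next compound to be measured. It differs from compound 3 as follows: 4-methylpiperazin-1-yl in place of 3-(dimethylamino)pyrrolidin-1-yl on an aromatic carbon. Among the compounds with values here, this is again an exchange of one saturated amine-bearing ring for another at the same position, and the one comparable step, from compound 1 to compound 3, was flat. Within the data shown here, no other step on this position is available, so the expectation rests on that single comparison.

Compound 4 is therefore expected to show only a step of a 1.1-fold higher number from compound 3 to compound 4 (0.05 log units; within the scatter) in this assay, with no change beyond the scatter. The estimate for compound 4 is 5 L/kg, with a likely range from 3 L/kg to 8.5 L/kg.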

Compound 4, volume of distribution at steady state: 4.9 L/kg
Estimate against measurement, compound 4: 1.0-fold (0.01 log units) above; the measured number falls inside the stated range.
By their numbers in this assay, from the lowest: compounds 3, 4, 1 and 2 (each within the scatter of the next).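

At the aromatic carbon next to the ring nitrogen, 4-methylpiperazin-1-yl in place of 3-(dimethylamino)pyrrolidin-1-yl gives a 1.1-fold higher number from compound 3 to compound 4 (0.04 log units; within the scatter) in this assay, and the same group in place of 4-(dimethylamino)piperidin-1-yl gives a 1.0-fold lower number from compound 1 to compound 4 (0.02 log units; within the scatter) in this assay; the read-out at this position therefore holds across three saturated rings, now including one with two ring hetero atoms and no defined stereocentre. Going by these compounds alone, a second place can also be read for the first time: hydrogen in place of ethyl on a saturated chain carbon bound to an amine nitrogen gives a 1.3-fold lower number from compound 2 to compound 4 (0.10 log units; within the scatter) in the same read-out, so this change in the chain also stays within the scatter. No supporting information explains why these exchanges leave the read-out unmoved.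

The compounds shown leave open whether a carboxylic acid or a morpholine ring at this aromatic carbon would shift the volume of distribution beyond the scatter. Within the data shown here, they also leave open whether a chain longer than the one in compound 2, on the same amine nitrogen, would do so.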